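Plasma half-life of dianhydrohexitol diesters: ester-side swap

The source may report more compounds than this note shows. Statements on the series, on what has been measured and on what is new or still open speak of the compounds shown alone.

Measured so far:
compound 1 `CC(=O)Oc1ccccc1C(=O)O[C@H]1CO[C@H]2[C@@H]1OC[C@H]2OC(=O)c1cccc(O)c1`: 0.0183 h
compound 2 `COc1ccc(C(=O)O[C@@H]2CO[C@H]3[C@@H]2OC[C@@H]3OC(=O)c2ccccc2OC(C)=O)cc1`: 0.0525 h

Both compounds were run in an ADME assay on a cell-free system (plasma, Homo sapiens) for metabolic stability, with Plasma (Rattus norvegicus) as the target, read by HPLC, at pH 7.4; a higher number here means that the compound lasts longer, a lower number that the compound disappears faster. Compound 1 gives 0.0183 h, compound 2 gives 0.0525 h. For the measured compounds named here, compound 2 therefore stands highest of the two numbers so far, and its one neighbour is compound 1 at a 2.9-fold higher number from compound 1 to compound 2 (0.46 log units; beyond the scatter), a modest step that is nevertheless beyond the scatter.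

Compound 3 `CC(=O)Oc1ccccc1C(=O)O[C@H]1CO[C@H]2[C@@H]1OC[C@H]2OC(=O)CCO[N+](=O)[O-]` is not yet measured in this assay. It differs from compound 2 as follows: 2-(nitrooxy)ethyl in place of 4-methoxyphenyl on a carbonyl carbon. Going by the values given here, the only measured step, a 2.9-fold higher number from compound 1 to compound 2 (0.46 log units; beyond the scatter), exchanges one six-membered aromatic ring for another at the same carbonyl carbon; it does not cover the loss of the ring altogether, so it bears on compound 3 only in showing that this position moves the half-life in this assay by a modest amount. Among the compounds with values here, no step shows the direction for a chain without a ring at this carbonyl carbon.

On that thin basis compound 3 is expected to fall close to or somewhat under compound 2, a step of a 1.8-fold lower number from compound 2 to compound 3 (0.24 log units; within the scatter) in this assay, at the edge of the scatter. The estimate for compound 3 is 0.03 h, with a range from 0.01 h to 0.09 h.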

Compound 3, half-life: 0.065 h
The estimate for compound 3 lay 2.2-fold (0.34 log units) below the measured number; low and high end bracket the measured number.
By their numbers in this assay, from the lowest: compound 1; then compounds 2 and 3 (each within the scatter of the next).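

In this assay, the carbonyl carbon does not need an aromatic ring to match compound 2: 2-(nitrooxy)ethyl in place of 4-methoxyphenyl gives a 1.2-fold higher number from compound 2 to compound 3 (0.09 log units; within the scatter), so the ring and the open chain cannot be told apart here. Set against compound 1, the same chain gives a 3.6-fold higher number from compound 1 to compound 3 (0.55 log units; beyond the scatter), which leaves compound 1, with its 3-hydroxyphenyl group, alone at the low end of these three compounds, while two quite different groups, one with a ring and one without, sit together above it. No supporting data are available to explain these half-lives.

Open, going by these compounds, is whether the nitrooxy group contributes anything to the number for compound 3, which a plain ethyl group or a longer chain at the same carbonyl carbon would test. Also open, on these data alone, is whether the low number for compound 1 follows from the hydroxyl on its ring, which an unsubstituted phenyl group would help to settle, and how a chain ending in an amine or a carboxylic acid would behave at this position.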